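Swapping Fluoro for Methoxy on the Amide Aryl Ring

This account rests on a few compounds, and the source may have more. Where it says the series, first, only, none or still open, it means among the compounds named here.

Measured compounds and their numbers in a functional assay on CHO cells for antagonist activity at Orexin receptor type 2 (Homo sapiens), read by FLIPR and calcium flux; on this read-out higher numbers stand for weaker inhibition and lower numbers for stronger inhibition:
Compound 1 `Cc1occc1-c1nnc(SCC(=O)Nc2ccc(F)c(Cl)c2)n1Cc1ccco1` gives 39.8 nM.
Compound 2 `Cc1ccc(NC(=O)CSc2nnc(-c3ccoc3C)n2Cc2ccco2)cc1` gives 39.8 nM.
Compound 3 `Cc1occc1-c1nnc(SCC(=O)Nc2ccc(F)cc2)n1Cc1ccco1` gives 158 nM.

Compound 3 stands at the highest of the three numbers, so it is the weakest inhibitor of the set: going from compound 1 to compound 3 shows a 4.0-fold higher number from compound 1 to compound 3 (0.60 log units; beyond the scatter), and going from compound 2 to compound 3 shows a 4.0-fold higher number from compound 2 to compound 3 (0.60 log units; beyond the scatter). Compound 1 and compound 2 sit together, as no change at the digits printed from compound 1 to compound 2 (within the scatter) shows.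

Compound 4 `COc1ccc(NC(=O)CSc2nnc(-c3ccoc3C)n2Cc2ccco2)cc1` differs from compound 3 in one place: methoxy in place of fluoro on an aromatic carbon. Among the compounds with values here, the step that bears most directly on this is the one from compound 2 to compound 3, which exchanged a group on the same aromatic carbon and moved the number a 4.0-fold higher number from compound 2 to compound 3 (0.60 log units; beyond the scatter). Within the data shown here, no measured step here exchanges fluoro for methoxy, so the direction is uncertain; the one prior exchange at this carbon lowered the number, which suggests that replacing fluoro by another group need not weaken inhibition. The step from compound 3 to compound 4 in this assay is therefore expected to be about a 2.0-fold lower number from compound 3 to compound 4 (0.30 log units; within the scatter), though possibly within the scatter. For compound 4 the estimate is 80 nM, with a range from 25 nM to 250 nM.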

Compound 4, inhibition constant: 200 nM
Compound 4: the middle estimate sits 2.5-fold (0.40 log units) below what was measured, and the stated range covers the measured number.
By their numbers in this assay, from the lowest: compounds 1 and 2 (each within the scatter of the next); then compounds 3 and 4 (each within the scatter of the next).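

In this assay, methoxy in place of fluoro on this aromatic carbon, para to a large group, gives a 1.3-fold higher number from compound 3 to compound 4 (0.10 log units; within the scatter), so the assay does not separate the two groups, even though methoxy brings a hydrogen-bond acceptor that fluoro lacks. The earlier compounds showed only that fluoro at this position gives a higher number than methyl; methoxy now shows the same kind of separation from the methyl compound, with a 5.0-fold higher number from compound 2 to compound 4 (0.70 log units; beyond the scatter), and from the 3-chloro-4-fluorophenyl compound, with a 5.0-fold higher number from compound 1 to compound 4 (0.70 log units; beyond the scatter), so among these single groups at this position, methyl alone keeps the lower number. Nothing shown accounts for why methyl differs from fluoro and methoxy here, or why the 3-chloro-4-fluorophenyl compound matches the methyl compound.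

As far as these compounds go, it remains open whether other groups at this position, such as ethyl, a dimethylamino group or a carboxylic acid, would fall with methyl or with fluoro and methoxy. From the compounds shown here alone, it is also open whether this order of methyl, fluoro and methoxy would hold if another part of the shared core were changed.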